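The source may hold more compounds than are shown below. What is called first, only, known or untested is meant among the compounds shown, and "the series" means these compounds.

Measured compounds in an assay on isolated protein for binding affinity to erythropoietin receptor (Homo sapiens); a higher number here means a weaker inhibitor, a lower number a stronger inhibitor:

compound 1, `COC(=O)[C@H](CCCCNC(N)=O)N(C/C=C/c1cccc(Oc2ccccc2)c1)C/C=C/c1cccc(Oc2ccccc2)c1`, gives 35000 nM
compound 2, `COC(=O)[C@H](CCCCN)N(/C=C/Cc1cccc(Oc2ccccc2)c1)Cc1cccc(Oc2ccccc2)c1`, gives 30000 nM
compound 3, `COC(=O)[C@H](CCCCN)N(Cc1cccc(OCc2ccccc2)c1)Cc1cccc(OCc2ccccc2)c1`, gives 10000 nM

Compound 2 stands with the second highest of the three numbers in this assay. The value of compound 1 lies within the usual scatter of that of compound 2, so the two cannot be told apart. For the measured compounds named here, compound 3 gives the lower number of the set, and its gap to compound 2 lies beyond the scatter; no single-point step connects these two, so only the two values themselves speak here.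

Compound 4, `COC(=O)[C@H](CC(=O)O)N(/C=C/Cc1cccc(Oc2ccccc2)c1)Cc1cccc(Oc2ccccc2)c1`, has not yet been measured in this assay. It differs from compound 2 in one place: carboxy in place of 3-aminopropyl on a saturated chain carbon, two bonds along the chain from an amine nitrogen and a carbonyl carbon. Going by the values given here, no pair of measured compounds shows this kind of change, so there is nothing in the set to tell which way the number will move. Among the compounds with values here, all three measured numbers are high and lie within a narrow band, which is the only guide available. On that basis the step from compound 2 to compound 4 is expected to be small, most likely within the scatter, with the direction left open: a 1.3-fold higher number from compound 2 to compound 4 (0.12 log units; within the scatter). Compound 4 is therefore estimated at 40000 nM, with a range from 10000 nM to 150000 nM.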

Compound 4, half-maximal inhibitory concentration: 40000 nM
Compound 4: middle estimate and measured number agree at the digits printed; measured number inside the range.
By their numbers in this assay, from the lowest: compound 3; then compounds 2, 1 and 4 (each within the scatter of the next).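

In this assay, for the compounds shown here, carboxy in place of 3-aminopropyl on a saturated chain carbon, two bonds along the chain from an amine nitrogen and a carbonyl carbon, gives a 1.3-fold higher number from compound 2 to compound 4 (0.12 log units; within the scatter), the first reading of any change at this position. The two groups differ in their atoms and in what they end in, yet the numbers on either side of this step cannot be told apart, so on this core the amine-bearing chain is not required to keep the number where it stands, and neither group separates itself from the other. Nothing in the available evidence accounts for this result or bears on how either group acts at this position.

On these data alone, whether this position responds to any group at all remains open, since a longer chain ending in a carboxylic acid, a primary amide or a plain methyl group in the same place could each give a number beyond the scatter or one within it. As far as these compounds go, it is also open whether the same exchange would read alike on the core of compound 3, which carries the 4-aminobutyl group on a different pair of side arms.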